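This account rests on a few compounds, and the source may have more. Where it says the series, first, only, none or still open, it means among the compounds named here.

Measured in a functional assay on HL-60 cells (Homo sapiens) for cytotoxicity, read by WST assay, with a stated time of 48 h; on this read-out lower numbers stand for stronger inhibition and higher numbers for weaker inhibition:
- compound 1 `COc1cc(C(c2ccc(O)c(OC)c2)[C@H](C)C(C)C)ccc1O`: 17000 nM
- compound 2 `COc1cc(C(c2ccc(O)c(OC)c2)[C@H](C)[C@H](C)CO)ccc1O`: > 100000 nM (a limit of the assay, not a number)
- compound 3 `COc1cc(C(c2ccc(O)c(OC)c2)[C@@H](C)[C@@H](C)CF)ccc1O`: 38000 nM

Only two of these results are true numbers, and compound 3 has the higher one, so it inhibits less strongly than compound 1. The gap is modest: a 2.2-fold higher number from compound 1 to compound 3 (0.35 log units; beyond the scatter). Compound 2 can be placed only through its limit, which gives an at least 2.6-fold lower number from compound 2 to compound 3 (0.42 log units; beyond the scatter).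

The next compound is compound 4 `COc1cc(C(c2ccc(O)c(OC)c2)[C@@H](CO)C(C)C)ccc1O`. Its difference is 1-(hydroxymethyl)-2-methylpropyl in place of 2-(fluoromethyl)-1-methylpropyl on a saturated chain carbon bound to two aromatic carbons. The change sits on a saturated chain carbon bound to two aromatic carbons, where 1-(hydroxymethyl)-2-methylpropyl replaces 2-(fluoromethyl)-1-methylpropyl.

Among the compounds with values here, no measured step makes exactly this change, so the closest guide is compound 2, which also carries a hydroxy group, though within 2-(hydroxymethyl)-1-methylpropyl. Adding that hydroxy group gave an at least 5.8-fold higher number from compound 1 to compound 2 (0.76 log units; beyond the scatter), the largest shift seen here. Compound 4 is therefore expected to give a higher number than compound 3 in this assay, meaning weaker inhibition. The expected change is a 1.8-fold higher number from compound 3 to compound 4 (0.27 log units; within the scatter). Compound 4 could also end up at the limit of > 100000 nM in this assay, at which 1 of the 3 values shown sits. For compound 4 the estimated value is 70000 nM, within an expected range of 30000 nM to 160000 nM.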

Compound 4, half-maximal inhibitory concentration: > 100000 nM
Compound 4 was reported as a limit (the forecaster's own chance of this, stated with the estimate: 40%); middle value at least 1.4-fold (0.15 log units) away from the limit.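

In this assay the swap from the 2-(fluoromethyl)-1-methylpropyl of compound 3 to 1-(hydroxymethyl)-2-methylpropyl gives an at least 2.6-fold higher number from compound 3 to compound 4 (0.42 log units; beyond the scatter) and the swap from the 1,2-dimethylpropyl of compound 1 to the same group gives an at least 5.8-fold higher number from compound 1 to compound 4 (0.76 log units; beyond the scatter) on this read-out. The weak result of compound 2 is therefore no longer a single case: a hydroxy group goes with weak inhibition both in 2-(hydroxymethyl)-1-methylpropyl and in 1-(hydroxymethyl)-2-methylpropyl, and none of the compounds shown goes against this. Compound 4 is reported only as a limit of the assay, not a number, and the step from compound 2 to compound 4 cannot be read, so the two hydroxy placements cannot be ranked against each other: the limit of > 100000 nM in this assay, at which 2 of the 4 values shown sit.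

From the compounds shown here alone, it remains open whether the weak inhibition belongs to the hydroxy group itself, or whether a methoxy group or an amine on the same chain would behave alike. Also open, going by these compounds, is whether a longer chain ending in a hydroxy group would bring the result back to a true number.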